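Moving a fluoro substituent around an aromatic ring

A few compounds are considered here, and "the series" means these few. Any claim that something is new, unique, unknown or untested is made for them only; others in the source may bear on it.

Measured compounds:
compound 1, `O=C1NCCc2nc(C#Cc3ccccc3)sc21`: > 10000 nM
compound 2, `O=C1NCCc2nc(C#Cc3cccc(F)c3)sc21`: > 10000 nM

In an assay on HEK293 cells for negative allosteric modulation of metabotropic glutamate receptor 5 (Homo sapiens), read by FLIPR, with a stated time of 1 h (a higher number here means a weaker inhibitor, a lower number a stronger inhibitor), compound 1 gives > 10000 nM, which is a limit of the assay and not a number. Compound 2 in this assay gives > 10000 nM, also a limit and not a number. The step that the two limits leave unreadable from compound 1 to compound 2 therefore cannot be read, and both values sit at the limit of > 10000 nM in this assay, at which 2 of the 2 values shown sit. Compound 1 thus stands at the weak end of what the assay reports, with nothing more precise known about it.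

Compound 3, `O=C1NCCc2nc(C#Cc3ccccc3F)sc21`, is the compound not yet measured. It differs from compound 1 by fluoro in place of hydrogen on an aromatic carbon. Within the data shown here, the only measured step that bears on this change is a step that the two limits leave unreadable from compound 1 to compound 2, and since two limits leave its size unreadable, it gives no guidance on direction or size. No step beyond the scatter is known for any fluoro placement on this ring. The expectation is that compound 3 will also sit at the limit, so the step that the limit leaves unreadable from compound 1 to compound 3 is expected to be unreadable. For compound 3 in this assay the estimate is 15000 nM, with a range from 3000 nM to 60000 nM.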

Compound 3, half-maximal inhibitory concentration: > 10000 nM
Compound 3: no number, only a limit; the forecaster's own chance of this, stated with the estimate: 80%; the middle value is on the limit's open side.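

No step can be read from compound 1 to compound 3, since the values of both are limits of the assay and not numbers: the limit of > 10000 nM in this assay, at which 3 of the 3 values shown sit.

Compound 1, compound 2 and compound 3 leave open how weak each of them really is, and whether fluoro in place of hydrogen on this aromatic ring changes inhibition at all.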